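Extending the propyl chain on the shared core by one carbon

The source may hold more compounds than are shown below. What is called first, only, known or untested is meant among the compounds shown, and "the series" means these compounds.

Three analogues of the shared core have been measured in an assay on cell membranes for displacement of a labelled ligand from Sigma non-opioid intracellular receptor 1 (Rattus norvegicus); a higher number here means a weaker inhibitor, a lower number a stronger inhibitor. Compound 1 `O=c1sc2ccccc2n1CCCN1CCCCCC1` gives 4.1 nM. Compound 2 `CCCC(=O)c1ccc2c(c1)sc(=O)n2CCCN1CCCCCC1` gives 2.6 nM. Compound 3 `CCCc1ccc2c(c1)sc(=O)n2CCCN1CCCCCC1` gives 1.4 nM, the lowest of the three numbers, though only a 2.9-fold lower number from compound 1 to compound 3 (0.47 log units; beyond the scatter) is beyond the scatter, while a 1.9-fold lower number from compound 2 to compound 3 (0.27 log units; within the scatter) is within it.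

Compound 4 `CCCCc1ccc2c(c1)sc(=O)n2CCCN1CCCCCC1` differs from compound 3 by methyl in place of hydrogen on a saturated chain carbon, three bonds along the chain from an aromatic carbon. Among the compounds with values here, no measured pair shows this exact lengthening of a chain, so the expectation rests on the neighbouring steps: a 2.9-fold lower number from compound 1 to compound 3 (0.47 log units; beyond the scatter) was modest, and a 1.9-fold lower number from compound 2 to compound 3 (0.27 log units; within the scatter) was within the scatter. A one-carbon extension of a chain that already lowers the number only modestly is expected to leave the number about where compound 3 stands, with no step beyond the scatter in either direction; the expected step is a 1.2-fold lower number from compound 3 to compound 4 (0.07 log units; within the scatter). Compound 4 is therefore estimated at 1.2 nM, within a range from 0.5 nM to 3 nM.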

Compound 4, inhibition constant: 2.2 nM
Compound 4: the middle estimate sits 1.8-fold (0.26 log units) below what was measured, within the range that was stated.
By their numbers in this assay, from the lowest: compounds 3, 4, 2 and 1 (each within the scatter of the next, the first and the last beyond it).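

In this assay, lengthening propyl to butyl gives a 1.6-fold higher number from compound 3 to compound 4 (0.20 log units; within the scatter), so one more carbon at this place on the chain does not separate the two compounds. Butyl in place of propylcarbonyl gives a 1.2-fold lower number from compound 2 to compound 4 (0.07 log units; within the scatter), and butyl in place of hydrogen gives a 1.9-fold lower number from compound 1 to compound 4 (0.27 log units; within the scatter), whereas propyl in place of hydrogen gave a 2.9-fold lower number from compound 1 to compound 3 (0.47 log units; beyond the scatter); only the propyl step therefore clears the scatter from compound 1. Nothing shown here accounts for these steps.

The compounds shown leave open whether a longer chain such as pentyl or hexyl would move the number beyond the scatter from compound 3. Also open, as far as these compounds go, is what a branched chain such as isobutyl, or an amine or carboxylic acid at the end of the butyl chain, would do.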